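A few compounds are considered here, and "the series" means these few. Any claim that something is new, unique, unknown or untested is made for them only; others in the source may bear on it.

Measured so far:
- compound 1, `CC(C)c1ccc(-c2nc(SCc3cn(CC(=O)NC(=O)Nc4ccccn4)nn3)nc(Nc3ccccc3Cl)c2C#N)cc1`: 19700 nM
- compound 2, `CC(C)c1ccc(-c2nc(SCc3cn(CC(=O)NC(=O)Nc4ccccn4)nn3)nc(Nc3cccc(C(F)(F)F)c3)c2C#N)cc1`: > 64000 nM, a limit of the assay
- compound 3, `CC(C)c1ccc(-c2nc(SCc3cn(CC(=O)NC(=O)Nc4ccccn4)nn3)nc(Nc3ccccc3F)c2C#N)cc1`: > 64000 nM, a limit of the assay

Going by the values given here, in a functional assay on MGC-803 cells (Homo sapiens) for inhibition, read by MTT assay, with a stated time of 72 h (on this read-out higher numbers stand for weaker inhibition and lower numbers for stronger inhibition), compound 1 gives 19700 nM, the only real number among the three. Compound 2 reaches only a limit in this assay. Compound 3 likewise reaches only a limit. Compound 4, `COc1ccccc1Nc1nc(SCc2cn(CC(=O)NC(=O)Nc3ccccn3)nn2)nc(-c2ccc(C(C)C)cc2)c1C#N`, changes compound 1 by methoxy in place of chloro on an aromatic carbon. Among the compounds with values here, two steps bear on this: an at least 3.2-fold higher number from compound 1 to compound 3 (0.51 log units; beyond the scatter), which replaces the same chloro on the same aromatic carbon, and an at least 3.2-fold higher number from compound 1 to compound 2 (0.51 log units; beyond the scatter). Both move toward weaker inhibition, so a weakening step is expected here too, a 1.8-fold higher number from compound 1 to compound 4 (0.25 log units; within the scatter), with a real chance that the result is again only a limit, as the limit of > 64000 nM in this assay, at which 2 of the 3 values shown sit, shows. Compound 4 is estimated at 35000 nM, expected between 12000 nM and 90000 nM.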

Compound 4, half-maximal inhibitory concentration: > 64000 nM
Compound 4 ended at the assay's limit; the forecaster's own chance of this, stated with the estimate: 40%; middle value at least 1.8-fold (0.26 log units) from the limit.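

In this assay, methoxy is the second group after fluoro to replace the chloro on this aromatic carbon, and it also weakens inhibition: an at least 3.2-fold higher number from compound 1 to compound 4 (0.51 log units; beyond the scatter). Compound 4 gives only a limit, not a number. Of the three groups tried at this place, only chloro keeps a real number, and the steps among compound 2, compound 3 and compound 4 cannot be read: the limit of > 64000 nM in this assay, at which 3 of the 4 values shown sit.

As far as these compounds go, how weak these three compounds really are remains open. So does whether a methyl, a bromo or an amine on the same carbon would keep a measurable value.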